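Sulfamoyl to cyano on the anilino-free working series

This account rests on a few compounds, and the source may have more. Where it says the series, first, only, none or still open, it means among the compounds named here.

In a functional assay on NCI-H460 cells (Homo sapiens) for antiproliferative activity, read by sulforhodamine B assay, with a stated time of 72 h (a lower number here means a stronger inhibitor, a higher number a weaker inhibitor), compound 3 (`NS(=O)(=O)c1ccc(Nc2nncc3ccccc23)cc1`) gives 17 nM and cannot be told apart from compound 1 (`Fc1ccc(Nc2nncc3ccccc23)cc1`), which gives 8.8 nM in the same read-out. Compound 2 (`O=S(=O)(Nc1ccccn1)c1ccc(Nc2nncc3ccccc23)cc1`) gives 43 nM, the higher number against compound 3 and beyond the scatter.

The next step leads to compound 4 (`N#Cc1ccc(Nc2nncc3ccccc23)cc1`), with cyano in place of sulfamoyl on an aromatic carbon, para to a large group (cyano in place of sulfamoyl on an aromatic carbon). For the measured compounds named here, no measured compound carries cyano, so the evidence is indirect. The nearest guide is the exchange at this same place, fluoro to sulfamoyl, which gave a 1.9-fold higher number from compound 1 to compound 3 (0.29 log units; within the scatter) and so no separation. The other measured step, a 2.5-fold lower number from compound 2 to compound 3 (0.40 log units; beyond the scatter), is modest and concerns the sulfonamide nitrogen, a group that leaves entirely in the new exchange, so it bears on the question only weakly.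

With only these steps as a guide, no change beyond the scatter is expected in this assay, and the expected step is a 1.2-fold lower number from compound 3 to compound 4 (0.08 log units; within the scatter) in a slightly lower direction at most. The estimate for compound 4 is 14 nM, with an expected range from 6 nM to 35 nM for repeat measurements.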

Compound 4, half-maximal inhibitory concentration: 7.7 nM
Compound 4: the middle estimate sits 1.8-fold (0.26 log units) above what was measured, within the range that was stated.
By their numbers in this assay, from the lowest: compounds 4, 1 and 3 (each within the scatter of the next, the first and the last beyond it); then compound 2.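

In this assay, for the compounds shown here, the exchange gives a 2.2-fold lower number from compound 3 to compound 4 (0.34 log units; beyond the scatter) and is the first change of the group on this aromatic carbon to clear the scatter, though only modestly. Cyano in place of fluoro at the same place gives a 1.1-fold lower number from compound 1 to compound 4 (0.06 log units; within the scatter) and so separates nothing, which leaves compound 1 and compound 4 indistinguishable while compound 3 sits within the scatter of compound 1 and beyond it from compound 4. No measurement at hand accounts for the separation between sulfamoyl and cyano or for its absence between sulfamoyl and fluoro.

The compounds shown leave open whether any group on this aromatic carbon gives a number clearly lower than those of fluoro and cyano, since a primary amine, a carboxylic acid or a longer chain such as an ethoxy group has no reading here. They also leave open whether the modest gap between sulfamoyl and cyano would hold for other substituents on the sulfonamide nitrogen than pyridin-2-yl, or in any read-out other than this antiproliferative one.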